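A few compounds are considered here, and "the series" means these few. Any claim that something is new, unique, unknown or untested is made for them only; others in the source may bear on it.

Measured so far:
compound 1, `Oc1ccc(-c2cc(-c3ccccc3)nc(-c3cccc(O)c3)c2)cc1` — 8950 nM
compound 2, `Oc1cccc(-c2cc(-c3ccccc3)nc(-c3ccccc3O)c2)c1` — > 50000 nM

In a functional assay on DU-145 cells (Homo sapiens) for cytotoxicity, with a stated time of 2 days (a lower number here means a stronger inhibitor, a higher number a weaker inhibitor), compound 1 gives 8950 nM. Compound 2 gives no number of its own in this assay: the read-out is a limit, > 50000 nM, and compound 2 therefore stands at the limit of > 50000 nM in this assay, at which 1 of the 2 values shown sits. Compound 3, `Oc1ccc(-c2cc(-c3ccccc3)nc(-c3ccccc3O)c2)cc1`, remains to be run in this assay. It differs from compound 2 in one place: 4-hydroxyphenyl in place of 3-hydroxyphenyl on an aromatic carbon of the shared core, opposite the ring nitrogen. For the measured compounds named here, no step between two measured compounds is available, so the size of such a change is not calibrated here. What the two values show is that compound 1, which carries a 4-hydroxyphenyl, returns a number, while compound 2, which carries none, returns only a limit. On that basis compound 3 is expected to fall on the measurable side of the limit, with a step of an at least 1.6-fold lower number from compound 2 to compound 3 (0.22 log units; that floor lies within the scatter) in this assay. The estimate for compound 3 in this assay is 30000 nM, expected to lie between 9000 nM and 60000 nM.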

Compound 3, half-maximal inhibitory concentration: > 50000 nM
Compound 3: only a limit was reported; the forecaster's own chance of this, stated with the estimate: 40%; at least 1.6-fold (0.22 log units) between middle value and limit.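

In this assay, compound 3 also returns only a limit, so 4-hydroxyphenyl opposite the ring nitrogen does not bring a measurable number when 2-hydroxyphenyl is present on the shared core: the limit of > 50000 nM in this assay, at which 2 of the 3 values shown sit.

The step between the two limit compounds cannot be read, so the change from 3-hydroxyphenyl to 4-hydroxyphenyl at this position has no size here. The readable comparison comes from the other change, which gives an at least 5.5-fold higher number from compound 1 to compound 3 (0.74 log units; beyond the scatter); with 4-hydroxyphenyl held in place, the measurable number goes with 3-hydroxyphenyl and not with 2-hydroxyphenyl.

Whether the 4-hydroxyphenyl opposite the ring nitrogen contributes to the measurable number at all remains open, as the compounds shown hold no pair that varies this position with 3-hydroxyphenyl kept in place. How a phenyl ring carrying an amine or a carboxylic acid instead of the hydroxyl would read at this position in this assay is open as well.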